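This account rests on a few compounds, and the source may have more. Where it says the series, first, only, none or still open, it means among the compounds named here.

Compound 1 `C=C(C)CCC[C@]1(C)C2=CCC[C@](C)(C[C@@H](OC(C)=O)C3=CC(=O)OC3O)[C@H]2CC[C@H]1C`: 2900 nM
Compound 2 `C=C(C)CCC[C@]1(C)C2=CCC[C@](C)(C[C@@H](O)C3=CC(=O)OC3O)[C@H]2CC[C@H]1C`: 2300 nM
Compound 3 `C=C(C)CC[C@]1(C)C2=CCC[C@](C)(C[C@@H](O)C3=CC(=O)OC3O)[C@H]2CC[C@H]1C`: 3600 nM

All three values come from a functional assay on HT-29 cells (Homo sapiens) for antiproliferative activity, read by XTT assay, with a stated time of 72 h; on this read-out higher numbers stand for weaker inhibition and lower numbers for stronger inhibition. Compound 2 cannot be told apart from its two neighbours on these numbers. The measured steps are a 1.3-fold lower number from compound 1 to compound 2 (0.10 log units; within the scatter) and a 1.6-fold higher number from compound 2 to compound 3 (0.19 log units; within the scatter).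

The unmeasured compound 4 `C=C(C)CCC[C@]1(C)C2=CCC[C@](C)(C[C@H](O)c3ccoc3)[C@H]2CC[C@H]1C` departs from compound 2 in one place: a group of 7 heavy atoms (5 carbon, 2 oxygen; one five-membered aromatic ring with 1 hetero atom) in place of a group of 9 heavy atoms (5 carbon, 4 oxygen; one five-membered non-aromatic ring with 1 hetero atom), on a saturated chain carbon bound to a saturated ring carbon. The group that enters is (furan-3-yl)(hydroxy)methyl.

Neither measured step bears directly on this change. The first swaps acetyl for hydrogen on an oxygen, and the second alters the chain carrying the 2-methylprop-2-en-1-yl group. All three measured compounds keep the five-membered non-aromatic ring that compound 4 gives up, so the data contain no measurement of what losing it does. They show only that the two edits elsewhere stayed small, and they cannot be carried over to this larger replacement. A step beyond the scatter is therefore plausible, and a higher number seems the likelier direction, though this is a judgement with wide uncertainty.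

In this assay the expected step is a 3.0-fold higher number from compound 2 to compound 4 (0.48 log units; beyond the scatter).

For compound 4 the estimated value is 7000 nM, with an expected range of 2000 nM to 25000 nM.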

Compound 4, half-maximal inhibitory concentration: 63100 nM
Beside the measured number, compound 4's estimate is 9.0-fold (0.95 log units) below it; measured number above the stated range.
By their numbers in this assay, from the lowest: compounds 2, 1 and 3 (each within the scatter of the next); then compound 4.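

In this assay, going by these compounds alone, putting (furan-3-yl)(hydroxy)methyl in place of the group that carries the five-membered non-aromatic ring gives a 27-fold higher number from compound 2 to compound 4 (1.44 log units; beyond the scatter), the only step in this set that lies beyond the scatter. The acetyl and chain edits stayed within the scatter, so this place, on a saturated chain carbon bound to a saturated ring carbon, is the first shown where a change clearly moves the number, and the weaker inhibition shows that the furan group does not stand in for the group it replaces. The swap changes several things at once, including the ring type and the counts of oxygen atoms, hydrogen-bond donors and acceptors, and nothing available explains which of these matters.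

The compounds shown leave open which part of the departing group accounts for the step; a methoxy group on the five-membered non-aromatic ring in place of its hydroxyl, or a thiophene in place of the furan, would begin to separate these parts. From the compounds shown here alone, it also remains open whether the acetyl and chain edits would stay as small on the furan series.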